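Swapping a furan-bearing amine for a pyridinyl amine

The source may hold more compounds than are shown below. What is called first, only, known or untested is meant among the compounds shown, and "the series" means these compounds.

In a functional assay on MCF7 cells (Homo sapiens) for inhibition, read by CCK-8 assay, with a stated time of 48 h (a higher number here means a weaker inhibitor of growth, a lower number a stronger inhibitor of growth), compound 1 `Cc1ccccc1Nc1nc(NC2CCCCC2)ncc1Cl` gives > 100000 nM and this is a limit of the assay. In this assay compound 2 `Cc1ccccc1Nc1nc(NCc2ccco2)ncc1Cl` gives > 100000 nM and this too is a limit. Compound 2 therefore has no number of its own and sits with compound 1 at the limit of > 100000 nM in this assay, at which 2 of the 2 values shown sit, in the data so far.

Compound 3 `Cc1ccccc1Nc1nc(Nc2ccccn2)ncc1Cl` differs from compound 2 in one place, with pyridin-2-yl in place of (furan-2-yl)methyl on a nitrogen on an aromatic ring while the shared core stays as it was.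

Among the compounds with values here, only one measured step bears on this change, namely a step that the two limits leave unreadable from compound 1 to compound 2 and it offers no size to carry forward. Little change is thus expected in this assay and any readable shift should be toward stronger inhibition, since compound 3 can otherwise only remain at the limit. The expected step is an at least 1.6-fold lower number from compound 2 to compound 3 (0.22 log units; that floor lies within the scatter) and it is an uncertain one. For compound 3 the estimated value is 60000 nM with an expected range from 10000 nM to 200000 nM and a real chance of only a limit.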

Compound 3, concentration for 50% growth inhibition: 31400 nM
Compound 3: middle estimate off by 1.9-fold (0.28 log units), on the high side; low and high end bracket the measured number.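

Compound 3 is the only compound shown with a number of its own in this assay, while compound 1 and compound 2 stay at a limit of the assay: the limit of > 100000 nM in this assay, at which 2 of the 3 values shown sit.

Within the data shown here, this gives the change on the nitrogen a readable direction for the first time, although the step from compound 1 to compound 2 cannot be read. Pyridin-2-yl in place of (furan-2-yl)methyl gives an at least 3.1-fold lower number from compound 2 to compound 3 (0.50 log units; beyond the scatter), and pyridin-2-yl in place of cyclohexyl gives an at least 3.1-fold lower number from compound 1 to compound 3 (0.50 log units; beyond the scatter). The first of these steps keeps the counts of heavy atoms, hydrogen-bond donors and hydrogen-bond acceptors unchanged, yet it exchanges a five-membered aromatic ring for a six-membered one and removes the carbon that linked the ring to the amino nitrogen.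

Going by these compounds, both steps start from a limit, so their full size remains open. On these data alone, it also remains open whether the gain follows the ring nitrogen of pyridin-2-yl or the direct attachment of the ring, a question that phenyl, pyridin-3-yl or (pyridin-2-yl)methyl on the same nitrogen would bear on.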